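A few compounds are considered here, and "the series" means these few. Any claim that something is new, unique, unknown or untested is made for them only; others in the source may bear on it.

Notes on the series. In a functional assay on CHO cells for agonist activity at Free fatty acid receptor 1 (Homo sapiens) (a higher number here means that more compound is needed for the effect, a lower number that less compound is needed), compound 1 `Cc1nc(-c2ccc(C(F)(F)F)cc2)sc1CNc1ccc(OCC(=O)O)cc1` gives 288 nM. Compound 2 `CC(C)(Oc1ccc(NCc2cccc(Oc3ccccc3)c2)cc1)C(=O)O` gives only a limit in this assay, < 10000 nM, and no number; this is the limit of < 10000 nM in this assay, at which 1 of the 2 values shown sits. Compound 3 `CC(C)NC(=O)[C@H]1C[C@@H]1c1ccc(NCc2cccc(Oc3ccccc3)c2)cc1` has not yet been measured. The change from compound 2 to compound 3 is 2-(isopropylcarbamoyl)cyclopropyl in place of 1-carboxy-1-methylethoxy on an aromatic carbon. Going by the values given here, no measured step covers this change, and compound 2 stands only at a limit, so the direction stays open; the step expected here is a step that the limit leaves unreadable from compound 2 to compound 3, taken as nothing beyond the scatter. Compound 3 is estimated at 3000 nM in this assay, with a range from 500 nM to 15000 nM.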

Compound 3, half-maximal effective concentration: 12.6 nM
The estimate for compound 3 lay 240-fold (2.38 log units) above the measured number, and the stated range ends above it.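

Going by these compounds alone, compound 2 stands only at a limit, so no step from it to compound 3 can be read: the limit of < 10000 nM in this assay, at which 1 of the 3 values shown sits. The compounds shown leave open what size of change 2-(isopropylcarbamoyl)cyclopropyl in place of 1-carboxy-1-methylethoxy brings.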